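A few compounds are considered here, and "the series" means these few. Any claim that something is new, unique, unknown or untested is made for them only; others in the source may bear on it.

In a functional assay on DU-145 cells (Homo sapiens) for inhibition, read by trypan blue exclusion, with a stated time of 72 h (a higher number here means a weaker inhibitor, a lower number a stronger inhibitor), compound 3 (`Cc1ccc(S(=O)(=O)c2cc3cnc(Nc4cnc5c(c4)CC(=O)N5)nc3n(C)c2=O)cc1`) gives 15000 nM. This lies within the scatter of compound 1 (`Cn1c(=O)c(S(=O)(=O)c2ccc(C(=O)O)cc2)cc2cnc(Nc3ccc4[nH]ccc4c3)nc21`) at 10000 nM, while compound 2 (`COc1ccc(S(=O)(=O)c2cc3cnc(Nc4ccc5[nH]ccc5c4)nc3n(C)c2=O)cc1`) stands well apart at 500 nM. Compound 4 (`Cc1ccc(S(=O)(=O)c2cc3cnc(Nc4ccc5[nH]ccc5c4)nc3n(C)c2=O)cc1`) follows from compound 3 by a group of 9 heavy atoms (8 carbon, 1 nitrogen; one five-membered aromatic ring with 1 hetero atom, one six-membered aromatic ring of carbon only) in place of a group of 10 heavy atoms (7 carbon, 2 nitrogen, 1 oxygen; one five-membered non-aromatic ring with 1 hetero atom, one six-membered aromatic ring with 1 hetero atom), on a nitrogen on an aromatic ring. For the measured compounds named here, no measured step changes this group. Going by the values given here, the only measured step, a 20-fold lower number from compound 1 to compound 2 (1.30 log units; beyond the scatter), lies at another place, and both of its compounds already carry the 1H-indol-5-yl group. A large step to a lower number is expected in this assay because compound 2 carries that group at 500 nM. The expected step is a 25-fold lower number from compound 3 to compound 4 (1.40 log units; beyond the scatter). Compound 4 is estimated at 600 nM, within an expected range of 150 nM to 2500 nM.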

Compound 4, half-maximal inhibitory concentration: 750 nM
Compound 4: middle estimate off by 1.3-fold (0.10 log units), on the low side; the measured number falls inside the stated range.
By their numbers in this assay, from the lowest: compounds 2 and 4 (each within the scatter of the next); then compounds 1 and 3 (each within the scatter of the next).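

For the compounds shown here, the step of a 20-fold lower number from compound 3 to compound 4 (1.30 log units; beyond the scatter) in this assay is the first measured change on this nitrogen, and it shows that exchanging this group for 1H-indol-5-yl alone, with the rest of the molecule unchanged, gives a large step. With 1H-indol-5-yl in place, methyl in place of methoxy gives a 1.5-fold higher number from compound 2 to compound 4 (0.18 log units; within the scatter), which is within the scatter, while methyl in place of carboxy gives a 13-fold lower number from compound 1 to compound 4 (1.12 log units; beyond the scatter). No available evidence explains these differences.

From the compounds shown here alone, it remains open whether a plain phenyl group on this nitrogen would match 1H-indol-5-yl. Going by these compounds, an amine or a nitrile in place of the methyl also remains open.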